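Methoxy in Place of Methyl: Weighing a Small Change

The source may hold more compounds than are shown below. What is called first, only, known or untested is meant among the compounds shown, and "the series" means these compounds.

Of the compounds shown here, two sharing one core have so far been measured in a functional assay on KB cells (Homo sapiens) for cytotoxicity, read by MTT assay, with a stated time of 72 h; a higher number here means that more compound is needed for the effect, a lower number that less compound is needed. Compound 1 `O=c1cc(Nc2ccccc2)cc(-c2ccccc2)o1` gives 0.13 uM. Compound 2 `Cc1ccc(Nc2cc(-c3ccccc3)oc(=O)c2)cc1` carries a methyl on an aromatic carbon where compound 1 carries hydrogen; in this assay compound 2 gives 0.064 uM. Among the compounds with values here, the single measured step, a 2.0-fold lower number from compound 1 to compound 2 (0.31 log units; beyond the scatter), leaves compound 2 with the lowest of the two numbers, its nearest neighbour being compound 1.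

Compound 3 `COc1ccc(Nc2cc(-c3ccccc3)oc(=O)c2)cc1` has not yet been measured in this assay. It differs from compound 2 in one place: methoxy in place of methyl on an aromatic carbon. Within the data shown here, no measured step bears directly on this exchange; the one step known, from hydrogen to methyl, concerns a different pair of groups on that aromatic carbon and was itself modest. With so little to go on, the expectation is a step no larger than that one, in either direction, and most likely within the scatter. Compound 3 is therefore expected to give about 0.08 uM, with a plausible range from 0.03 uM to 0.2 uM, meaning an expected step of a 1.3-fold higher number from compound 2 to compound 3 (0.10 log units; within the scatter).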

Compound 3, concentration for half-maximal effect: 0.16 uM
Compound 3: the middle estimate sits 2.0-fold (0.30 log units) below what was measured; low and high end bracket the measured number.
By their numbers in this assay, from the lowest: compound 2; then compounds 1 and 3 (each within the scatter of the next).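

In this assay, the step of methoxy in place of methyl gives a 2.5-fold higher number from compound 2 to compound 3 (0.40 log units; beyond the scatter) and so shows that this place, para to a large group, responds to which group sits there and not merely to whether hydrogen has been replaced: the lower number that came with methyl does not carry over to methoxy, which has one more heavy atom, an oxygen. Methoxy in place of hydrogen gives a 1.2-fold higher number from compound 1 to compound 3 (0.09 log units; within the scatter), so compound 1 and compound 3 cannot be told apart here, and compound 2 alone has steps beyond the scatter to both other compounds. No measurement is at hand that would explain why methyl and methoxy differ at this place.

The compounds shown hold only hydrogen, methyl and methoxy at this place, so it stays open whether an ethyl chain, a chlorine atom or an amine would fall nearer to compound 2 or to compound 3. They also leave open whether methyl would keep its lower number at another place on the same ring, or in another cell line.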